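Working notes: hydroxy on the phenyl of compound 2

The source may report more compounds than this note shows. Statements on the series, on what has been measured and on what is new or still open speak of the compounds shown alone.

Compound 1 `Cn1c(/C=C/C(=O)c2cccc(O)c2)cc(Br)c1Br` gives >= 100000 nM
Compound 2 `Cn1c(-c2cc(-c3ccccc3)no2)cc(Br)c1Br` gives >= 100000 nM
Compound 3 `Cn1c(-c2cc(-c3ccc[nH]3)no2)cc(Br)c1Br` gives >= 100000 nM

Compound 2 gives >= 100000 nM in a functional assay on WRL68 cells (Homo sapiens) for cytotoxicity, read by MTT assay, with stated times of 6 h and 48 h (on this read-out lower numbers stand for stronger inhibition and higher numbers for weaker inhibition), and this is a limit of the assay, not a number. Among the measured compounds shown here, the series so far shows the limit of >= 100000 nM in this assay, at which 3 of the 3 values shown sit, and no measured compound gives a number.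

Compound 4 `Cn1c(-c2cc(-c3ccccc3O)no2)cc(Br)c1Br` differs from compound 2 by hydroxy in place of hydrogen on an aromatic carbon and the change is hydroxy in place of hydrogen on an aromatic carbon, ortho to a large group.

For the measured compounds named here, the only measured step from compound 2 is a step that the two limits leave unreadable from compound 2 to compound 3 and it exchanges a whole group, so it offers no size to carry over. Compound 1 also carries a hydroxy group and its >= 100000 nM is likewise a limit.

No step beyond the scatter is therefore expected in this assay for this change. The expected step is a number no higher from compound 2 to compound 4 (the limit leaves the size open) and it remains uncertain while compound 2 has only a limit. For compound 4 the estimated value is 100000 nM with an expected range from 40000 nM to 200000 nM and a limit rather than a number is the likely report.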

Compound 4, half-maximal inhibitory concentration: >= 100000 nM
Compound 4 gave a limit, no number (the forecaster's own chance of this, stated with the estimate: 85%); the middle value lies on the limit itself.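

Compound 2 and compound 4 each give only a limit, not a number, so no step can be read between them in this assay and the series stays at one limit: the limit of >= 100000 nM in this assay, at which 4 of the 4 values shown sit. The compounds shown leave open how large any change from hydroxy in place of hydrogen would be.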